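This account rests on a few compounds, and the source may have more. Where it says the series, first, only, none or still open, it means among the compounds named here.

Compounds measured so far in a physicochemical assay for lipophilicity, read by HPLC, at pH 7.5; a higher number here means a more lipophilic compound, a lower number a more polar compound:

Compound 1, `CC[C@@H](Nc1c(C#N)c(-c2ccc(-c3ccccc3CO)cc2)nc2cnccc12)C(N)=O`, gives 2.1.
Compound 2, `CC[C@@H](Nc1c(C#N)c(-c2ccc(-c3ccccc3OC)cc2)nc2cnccc12)C(N)=O`, gives 2.7.
Compound 3, `CC[C@@H](Nc1c(C#N)c(-c2ccc(-c3ccccc3C(C)C)cc2)nc2cnccc12)C(N)=O`, gives 3.5.

Compound 3 stands highest of the three, with compound 2 nearest to it and compound 1 furthest; the rise was a number 0.80 log units higher from compound 2 to compound 3 (beyond the scatter) and a number 1.40 log units higher from compound 1 to compound 3 (beyond the scatter), both beyond the scatter.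

Compound 4, `CC[C@@H](Nc1c(C#N)c(-c2ccc(-c3ccccc3Cl)cc2)nc2cnccc12)C(N)=O`, is not yet measured. It differs from compound 3 in one place:

chloro in place of isopropyl on an aromatic carbon

Two of the measured steps bear on this change, as both end in the isopropyl that now leaves: the modest rise a number 0.80 log units higher from compound 2 to compound 3 (beyond the scatter) and the large rise a number 1.40 log units higher from compound 1 to compound 3 (beyond the scatter). For the measured compounds named here, no measured compound carries a chloro on that aromatic carbon, so there is no step that shows its own contribution, and the 1>2 step, a number 0.60 log units higher from compound 1 to compound 2 (beyond the scatter), does not touch the isopropyl. With the isopropyl gone and a single chlorine in its place, a downward step in this assay is expected for compound 4, smaller than the rise seen from compound 1, estimated as a number 0.70 log units lower from compound 3 to compound 4 (beyond the scatter). Compound 4 is therefore expected to give about 2.8, within the range 2.4 to 3.2.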

Compound 4, distribution coefficient: 2.9
Compound 4: the middle estimate sits 0.10 log units below what was measured; measured number inside the range.
By their numbers in this assay, from the lowest: compound 1; then compounds 2 and 4 (each within the scatter of the next); then compound 3.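

In this assay the change from 2-isopropylphenyl to 2-chlorophenyl brings a number 0.60 log units lower from compound 3 to compound 4 (beyond the scatter) even though neither group carries a hydrogen-bond donor or acceptor, so at this place that count alone does not fix the number. The chloro also gives a number 0.20 log units higher from compound 2 to compound 4 (within the scatter) and so cannot be told apart from the methoxy here. It stands clear of the hydroxymethyl, with a number 0.80 log units higher from compound 1 to compound 4 (beyond the scatter) as the step, so the four groups fall into three levels, with chloro and methoxy sharing the middle one.

From the compounds shown here alone, whether an amine, a carboxylic acid or a longer alkyl chain on this aromatic carbon would stay inside the span of these four groups remains open. Nothing at hand gives a cause for any of these steps.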